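Swapping a Methyl for Bromine on an Aromatic Ring

The compounds below may be only part of what the source reports. "The series", "measured", "known", "first", "only" and "open" are said of these compounds alone.

Compound 1 `COC(=O)[C@@]1(C)CCC=C2[C@@H]1CC[C@@H](C)[C@]2(C)Cc1c[nH]c2ccc(C)cc12` gives 17000 nM in a functional assay on A549 cells (Homo sapiens) for inhibition, read by sulforhodamine B assay, with a stated time of 48 h; a lower number here means a stronger inhibitor of growth, a higher number a weaker inhibitor of growth.
Compound 2 `COC(=O)[C@@]1(C)CCC=C2[C@@H]1CC[C@@H](C)[C@]2(C)Cc1c[nH]c2ccc(Br)cc12` gives 15000 nM in this assay.
Compound 3 `COC(=O)[C@@]1(C)CCC=C2[C@@H]1CC[C@@H](C)[C@]2(C)Cc1c(C)[nH]c2c(C)cccc12` gives 14000 nM in this assay.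

Compound 2 differs from compound 1 by bromo in place of methyl on an aromatic carbon and the measured step is a 1.1-fold lower number from compound 1 to compound 2 (0.05 log units; within the scatter). Compound 4 `COC(=O)[C@@]1(C)CCC=C2[C@@H]1CC[C@@H](C)[C@]2(C)Cc1c(C)[nH]c2c(Br)cccc12` has not been measured; it differs from compound 3 by bromo in place of methyl on an aromatic carbon. This is the same kind of change, but not the same: the earlier one sits "meta to a fused ring; para to a fused ring", while the new one sits "ortho to a fused ring; meta to a fused ring". How the cores of compound 1 and compound 3 differ is not broken down here.

From compound 3 to compound 4 a step of a 1.1-fold lower number from compound 3 to compound 4 (0.03 log units; within the scatter) is expected, resting on the small step of a 1.1-fold lower number from compound 1 to compound 2 (0.05 log units; within the scatter) between compound 1 and compound 2. Compound 4 is therefore estimated at 13000 nM, likely between 6000 nM and 30000 nM.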

Compound 4, concentration for 50% growth inhibition: 27000 nM
Estimate against measurement, compound 4: 2.1-fold (0.32 log units) below, and the stated range covers the measured number.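

The swap of methyl for bromo gives a 1.9-fold higher number from compound 3 to compound 4 (0.29 log units; within the scatter) in this assay, so this step, like the earlier one, is no larger than the differences seen between repeated measurements. Set side by side, the two steps cannot be told apart: the same change on two cores in this assay, a 1.1-fold lower number (0.05 log units; within the scatter) from compound 1 to compound 2 and a 1.9-fold higher number (0.29 log units; within the scatter) from compound 3 to compound 4, 2.2-fold (0.34 log units) apart, within the scatter of two such steps. This gives no sign that the change behaves differently on the two cores or at its two places on the ring, but two small steps do not prove that it would carry over unchanged to other cores.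

The compounds shown leave open whether a different group on that aromatic carbon, such as an amine, a carboxylic acid or a longer chain, would shift growth inhibition beyond the scatter.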